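This account rests on a few compounds, and the source may have more. Where it says the series, first, only, none or still open, it means among the compounds named here.

Compound 1 `COc1ccc(CNC(=O)c2cc(-c3cncc(C)c3)ncc2-c2cncc(F)c2)nc1OC` and compound 2 `COc1ccc(CNC(=O)c2cc(-c3cncc(C)c3)ncc2-c2cnccn2)nc1OC` share one core and differ only in the aromatic group on one aromatic carbon. In an assay on CHO cells for displacement of a labelled ligand from Orexin/Hypocretin receptor type 1 variant I408V (Homo sapiens), read by scintillation counting (a higher number here means a weaker inhibitor, a lower number a stronger inhibitor), compound 1 gives 17000 nM, and compound 2 gives 31000 nM. On the numbers shown, compound 2 stands at the upper end of the two, but the step of a 1.8-fold higher number from compound 1 to compound 2 (0.26 log units; within the scatter) is within the scatter, so the two values cannot be separated. Compound 3 `COc1ccc(CNC(=O)c2cc(-c3cncc(C)c3)ncc2N2CCC2)nc1OC` differs from compound 2 by azetidin-1-yl in place of pyrazin-2-yl on an aromatic carbon. Going by the values given here, no measured step bears directly on this change: the only step known swaps one six-membered aromatic ring for another and stays within the scatter, whereas the change to compound 3 brings in a four-membered non-aromatic ring. Both measured compounds are weak in this assay, and nothing in the data points to a large move in either direction. Compound 3 is therefore expected to remain in the same weak range, with an estimated step of a 1.6-fold lower number from compound 2 to compound 3 (0.19 log units; within the scatter). Compound 3 is estimated at 20000 nM, with a range from 5000 nM to 80000 nM.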

Compound 3, inhibition constant: 18000 nM
Beside the measured number, compound 3's estimate is 1.1-fold (0.05 log units) above it; the range from low to high includes it.
By their numbers in this assay, from the lowest: compounds 1, 3 and 2 (each within the scatter of the next).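

Going by these compounds alone, until now, this position, on an aromatic carbon of a six-membered aromatic ring with 1 nitrogen, had been seen only with one six-membered aromatic ring exchanged for another. Compound 3 extends the comparison to a four-membered non-aromatic ring: in this assay the exchange for pyrazin-2-yl gives a 1.7-fold lower number from compound 2 to compound 3 (0.24 log units; within the scatter) and the exchange for 5-fluoropyridin-3-yl gives a 1.1-fold higher number from compound 1 to compound 3 (0.02 log units; within the scatter), so azetidin-1-yl cannot be separated from either aromatic group, even with its smaller count of heavy atoms. Nothing available explains why these different rings give values that cannot be told apart.

On these data alone, all three compounds lie within the scatter of one another, so it remains open whether any group at this position can shift the number in this assay beyond the scatter. A morpholine ring, an open-chain amine such as dimethylamino, or a carboxylic acid would test this, and the compounds shown also leave open whether the 5-methylpyridin-3-yl group or the amide side of the shared core has more bearing on the value.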